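This account rests on a few compounds, and the source may have more. Where it says the series, first, only, none or still open, it means among the compounds named here.

Measured so far in a functional assay on NCI-H460 cells (Homo sapiens) for antiproliferative activity, read by MTT assay, with a stated time of 48 h; on this read-out higher numbers stand for weaker inhibition and lower numbers for stronger inhibition:

Compound 1, `CCCCCCC1(O)C(=O)Nc2ccc(Nc3ccc(OC)cc3)cc21`: > 100000 nM
Compound 2, `COc1ccc(Nc2ccc3c(c2)C(O)(Cc2ccccc2)C(=O)N3)cc1`: > 100000 nM
Compound 3, `CCCCCCC1(O)C(=O)Nc2ccc(Nc3ccc(Cl)cc3)cc21`: 30300 nM

The values of compound 1 and compound 2 in this assay are limits of the assay, not numbers. Going by the values given here, compound 3 gives the only number in this assay so far. Compound 1 and compound 3 differ in one place, (chloro in place of methoxy on an aromatic carbon), and that step, an at least 3.3-fold lower number from compound 1 to compound 3 (0.51 log units; beyond the scatter), is at least modest. Compound 2 arises from compound 1 by phenyl in place of pentyl on a saturated chain carbon bound to a saturated ring carbon; the step that the two limits leave unreadable from compound 1 to compound 2 cannot be read because of the limit of > 100000 nM in this assay, at which 2 of the 3 values shown sit.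

Compound 4, `O=C1Nc2ccc(Nc3ccc(Cl)cc3)cc2C1(O)Cc1ccccc1`, is not yet measured. It arises from compound 3 by phenyl in place of pentyl on a saturated chain carbon bound to a saturated ring carbon, the same change as from compound 1 to compound 2, at the same place. Since that earlier step gave no readable size, the expected step of a 1.3-fold higher number from compound 3 to compound 4 (0.12 log units; within the scatter) for compound 4 rests only on the number for compound 3, with a fair chance that compound 4 also returns a limit.

Compound 4 is expected in this assay at about 40000 nM, estimated between 12000 nM and 150000 nM.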

Compound 4, half-maximal inhibitory concentration: 20200 nM
Compound 4: middle estimate off by 2.0-fold (0.30 log units), on the high side; measured number inside the range.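

In this assay, chloro in place of methoxy on an aromatic carbon carries over in direction to the core bearing phenyl in place of pentyl, with an at least 4.9-fold lower number from compound 2 to compound 4 (0.69 log units; beyond the scatter). The size of this step cannot be set against the earlier one, so two cores show a shared direction and not a shared size: the same change on two cores in this assay, an at least 3.3-fold lower number (0.51 log units; beyond the scatter) from compound 1 to compound 3 and an at least 4.9-fold lower number (0.69 log units; beyond the scatter) from compound 2 to compound 4; the limit leaves it open whether they differ

With chloro in place, phenyl in place of pentyl on a saturated chain carbon bound to a saturated ring carbon gives a 1.5-fold lower number from compound 3 to compound 4 (0.18 log units; within the scatter), so this pair shows no difference beyond the scatter, while the same change with methoxy cannot be read: the limit of > 100000 nM in this assay, at which 2 of the 4 values shown sit.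

Still open, from the compounds shown here alone, is whether fluoro, bromo or trifluoromethyl in place of chloro on that aromatic carbon would move the number beyond the scatter of compound 3 and compound 4. Also open, going by these compounds, is whether a shorter chain, a cyclohexyl group or an amine-bearing chain in place of pentyl or phenyl would do so.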